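A few compounds are considered here, and "the series" means these few. Any claim that something is new, unique, unknown or untested is made for them only; others in the source may bear on it.

The series is read in an ADME assay on J774.1 cells (Mus musculus) for cytotoxicity, read by MTT assay, with a stated time of 48 h; a higher number here means a weaker inhibitor, a lower number a stronger inhibitor. Compound 1 (`Cc1c(C(=O)N/N=C/c2ccco2)no[n+]1[O-]`) gives > 400000 nM, which is a limit and not a number. Compound 2 (`Cc1c(C(=O)N/N=C/c2ccccc2)no[n+]1[O-]`) gives > 400000 nM, also a limit. Compound 3 (`Cc1c(C(=O)N/N=C/c2ccccn2)no[n+]1[O-]`) gives > 400000 nM, again a limit. Within the data shown here, compound 2 therefore has no number of its own, and the series so far shows only (the limit of > 400000 nM in this assay, at which 3 of the 3 values shown sit).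

Compound 4 (`Cc1c(C(=O)N/N=C/c2ccc(Br)cc2)no[n+]1[O-]`) has bromo in place of hydrogen on an aromatic carbon of compound 2, para to a large group: bromo in place of hydrogen on an aromatic carbon.

The measured steps that bear on this change the group on the carbon with a double bond to nitrogen: a step that the two limits leave unreadable from compound 1 to compound 2, a step that the two limits leave unreadable from compound 1 to compound 3 and a step that the two limits leave unreadable from compound 2 to compound 3. None of them has a readable size and none involves bromo. No step beyond the scatter is therefore expected in this assay, and no direction is expected. The expected step is a number no higher from compound 2 to compound 4 (the limit leaves the size open). For compound 4 the estimated value is 400000 nM, with an expected range from 150000 nM to 800000 nM.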

Compound 4, half-maximal inhibitory concentration: 162000 nM
Compound 4: the middle estimate sits 2.5-fold (0.39 log units) above what was measured, and the stated range covers the measured number.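

In this assay, bromo in place of hydrogen on an aromatic carbon, para to a large group, gives an at least 2.4-fold lower number from compound 2 to compound 4 (0.39 log units; beyond the scatter). This is the first change in the series with a readable step, and it makes compound 4 the only compound shown with a number of its own. The steps among compound 1, compound 2 and compound 3, which change the group on the carbon with a double bond to nitrogen, cannot be read, and the rest of the series remains at a limit: the limit of > 400000 nM in this assay, at which 3 of the 4 values shown sit.

From the compounds shown here alone, the true size of the step stays open, as does whether it is specific to bromo or would also appear with chloro, methoxy, an amine or a carboxylic acid at this position. Also open, going by these compounds, is whether bromo would give a similar step on the rings of compound 1 and compound 3.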